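Working notes: from compound 3 to compound 4

A few compounds are considered here, and "the series" means these few. Any claim that something is new, unique, unknown or untested is made for them only; others in the source may bear on it.

Measured so far:
compound 1 `O=C(CCCCCCc1nc(-c2ccccc2Cl)no1)NO` — 3650 nM
compound 2 `O=C(CCCCCCc1nc(-c2cccc([N+](=O)[O-])c2)no1)NO` — 2380 nM
compound 3 `Nc1ccccc1NC(=O)CCCCCCc1nc(-c2ccccc2)no1` — a limit only, > 10000 nM

In an assay on isolated protein for inhibition of histone deacetylase 8 (Homo sapiens), read by fluorescence, with a stated time of 10 min (on this read-out higher numbers stand for weaker inhibition and lower numbers for stronger inhibition), compound 1 gives 3650 nM and compound 2 gives 2380 nM. Compound 3 reaches only > 10000 nM in this assay; that is a limit of the assay and not a number. Compound 3 therefore stands at the weak end of the numbers shown, at the limit of > 10000 nM in this assay, at which 1 of the 3 values shown sits. Going by the values given here, compounds 1 and 2 share one end group, compound 3 carries another, and no two of the three differ in only one place, so no measured step is available.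

Compound 4 `Nc1ccccc1NC(=O)CCCCCCc1nc(-c2ccc([N+](=O)[O-])cc2)no1` differs from compound 3 in one place: nitro in place of hydrogen on an aromatic carbon, para to a large group. With compound 3 already at the limit, the step is expected to stay within the usual scatter; the expected step in this assay is a step that the limit leaves unreadable from compound 3 to compound 4, with no clear direction beyond the scatter. Compound 4 is therefore estimated at 15000 nM in this assay, with a range of 5000 nM to 50000 nM, and it is likely that only a limit is reported again.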

Compound 4, half-maximal inhibitory concentration: > 10000 nM
Compound 4 was reported as a limit; the forecaster's own chance of this, stated with the estimate: 70%; the middle value does not contradict the limit.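

Compound 3 and compound 4 both stand at a limit of this assay and not at a number, so no step can be read between them: the limit of > 10000 nM in this assay, at which 2 of the 4 values shown sit.

The compounds shown leave open how far phenyl to 4-nitrophenyl shifts inhibition, and how the end group of compound 1 and compound 2 compares with that of compound 3 and compound 4 with all else the same.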